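Phenyl carbonate to dimethyl carbamate on a shared core

A few compounds are considered here, and "the series" means these few. Any claim that something is new, unique, unknown or untested is made for them only; others in the source may bear on it.

Two compounds have been measured in an assay (Oryctolagus cuniculus) for inhibition of platelet-activating factor receptor (Cavia porcellus); on this read-out higher numbers stand for weaker inhibition and lower numbers for stronger inhibition:
compound 1 `C/C1=C\CC[C@@]2(C)O[C@@H]2C(=O)[C@@H]2CC[C@@H](C)[C@](C)(CC1)[C@H]2CO` gives 1300 nM;
compound 2 `C/C1=C\CC[C@@]2(C)O[C@@H]2C(=O)[C@@H]2CC[C@@H](C)[C@](C)(CC1)[C@H]2COC(=O)Oc1ccccc1` gives 550 nM.

Compound 2 holds the lower of the two numbers in this assay; its nearest neighbour is compound 1, separated by the step of a 2.4-fold lower number from compound 1 to compound 2 (0.37 log units; beyond the scatter). Compound 3 `C/C1=C\CC[C@@]2(C)O[C@@H]2C(=O)[C@@H]2CC[C@@H](C)[C@](C)(CC1)[C@H]2COC(=O)N(C)C` differs from compound 2 by dimethylamino in place of phenoxy on a carbonyl carbon. Among the measured compounds shown here, no measured step alters a group on that carbonyl carbon; the only known step, a 2.4-fold lower number from compound 1 to compound 2 (0.37 log units; beyond the scatter), concerns whether the phenoxycarbonyl is present at all, so it bears on this change only loosely. Compound 3 is therefore expected to show a 1.5-fold higher number from compound 2 to compound 3 (0.16 log units; within the scatter), not clearly beyond the scatter. Compound 3 is estimated at 800 nM in this assay, within 300 nM to 2200 nM.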

Compound 3, half-maximal inhibitory concentration: 180 nM
Beside the measured number, compound 3's estimate is 4.4-fold (0.65 log units) above it, and the stated range ends above it.
By their numbers in this assay, from the lowest: compound 3; then compound 2; then compound 1.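

In this assay, the group on the carbonyl carbon proves to matter: a 3.1-fold lower number from compound 2 to compound 3 (0.49 log units; beyond the scatter), so the phenoxy ring is not required at this position. Dimethylcarbamoyl in place of hydrogen on the oxygen gives a 7.2-fold lower number from compound 1 to compound 3 (0.86 log units; beyond the scatter), showing that a group without a ring can carry this gain. Nothing available explains why dimethylamino outdoes phenoxy here.

From the compounds shown here alone, it remains open whether diethylamino or morpholine on that carbonyl carbon would continue the trend. Going by these compounds, it is also open whether a plain acetyl group on the oxygen would keep the gain.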